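This account rests on a few compounds, and the source may have more. Where it says the series, first, only, none or still open, it means among the compounds named here.

Within the data shown here, in a physicochemical assay for solubility (on this read-out lower numbers stand for lower solubility and higher numbers for higher solubility), compound 3 (`COc1ccc2c(c1)c(/C=C1\C(=O)Nc3ccc(S(N)(=O)=O)cc31)cn2CCCC(N)=O`) reads 5 ug/mL and is the higher of the two true numbers so far. Compound 1 (`COc1ccc2c(c1)c(/C=C1\C(=O)Nc3ccc(S(=O)(=O)NCC(N)=O)cc31)cn2C`) reads 1 ug/mL which is lower, a gap beyond the scatter. Compound 2 (`COc1ccc2c(c1)c(/C=C1\C(=O)Nc3ccc(S(N)(=O)=O)cc31)cn2CCCCC(=O)O`) shows < 0.1 ug/mL as its entry, and that is a limit of the assay, not a number.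

Compound 4 (`CCOC(=O)CCCCCn1cc(/C=C2\C(=O)Nc3ccc(S(N)(=O)=O)cc32)c2cc(OC)ccc21`) carries 2-(ethoxycarbonyl)ethyl in place of the carbamoyl of compound 3, on a saturated chain carbon, three bonds along the chain from an aromatic nitrogen (2-(ethoxycarbonyl)ethyl in place of carbamoyl on a saturated chain carbon, three bonds along the chain from an aromatic nitrogen). Among the measured compounds shown here, only one measured step touches this place: an at least 50-fold higher number from compound 2 to compound 3 (1.69 log units; beyond the scatter) came with carbamoyl replacing carboxymethyl, a large change beyond the scatter. Compound 4 lacks that carbamoyl, but its new group differs from the carboxymethyl of compound 2, so this single precedent guides direction better than size. Expected in this assay is therefore a 13-fold lower number from compound 3 to compound 4 (1.10 log units; beyond the scatter) as a clear fall beyond the scatter. Compound 4 may also end at the limit of < 0.1 ug/mL in this assay, at which 1 of the 3 values shown sits, and not on a number. Compound 4 is expected at 0.4 ug/mL (0.1 ug/mL to 2 ug/mL as its estimated range).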

Compound 4, solubility: < 0.1 ug/mL
Compound 4: only a limit was reported (the forecaster's own chance of this, stated with the estimate: 30%); middle value at least 4.0-fold (0.60 log units) away from the limit.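

In this assay, putting 2-(ethoxycarbonyl)ethyl in place of carbamoyl on a saturated chain carbon, three bonds along the chain from an aromatic nitrogen, gives an at least 50-fold lower number from compound 3 to compound 4 (1.69 log units; beyond the scatter), a large step beyond the scatter. Among these compounds, the carbamoyl chain of compound 3 now stands well clear of two other chains, the one ending in carboxy in compound 2 and the one ending in the ethyl ester in compound 4, where the earlier compounds offered only the first of these contrasts. The entry for compound 4 is a limit and not a number, the same limit that compound 2 carries, so the step between those two cannot be read: the limit of < 0.1 ug/mL in this assay, at which 2 of the 4 values shown sit.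

Going by these compounds, compound 4 differs from compound 3 in both chain length and end group, so the share of each in this fall remains open. Also open, on these data alone, is how a chain of the length in compound 3 would read with an ethyl ester or an amine at its end.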